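Benzyl in place of methyl on the core of compound 3

The source may report more compounds than this note shows. Statements on the series, on what has been measured and on what is new or still open speak of the compounds shown alone.

Compound 3 `Cn1nc(-c2ccccc2)c2cc(C(=N)Nc3cccc(C(F)(F)F)c3)ncc21` gives 21400 nM in a functional assay on MDA-MB-231 cells (Homo sapiens) for cytotoxicity, read by MTT assay, with a stated time of 72 h (on this read-out lower numbers stand for stronger inhibition and higher numbers for weaker inhibition), the lowest of the two numbers reported, with compound 2 closest. Compound 2 `N=C(Nc1cccc(C(F)(F)F)c1)c1cc2c(-c3ccccc3)n[nH]c2cn1` gives 22300 nM in this assay. Among the measured compounds shown here, the one step among measured compounds, a 1.0-fold lower number from compound 2 to compound 3 (0.02 log units; within the scatter), is within the scatter. For the measured compounds named here, compound 1 `COc1ccc(Cn2nc(-c3ccccc3)c3cc(C(=N)Nc4cccc(C(F)(F)F)c4)nc(NC4CCCCC4)c32)cc1` reaches only the limit of this assay, > 50000 nM, which is the limit of > 50000 nM in this assay, at which 1 of the 3 values shown sits, and not a number; compound 1 carries the same group as compound 4 but also a cyclohexylamino group, so no single step links it to compound 3 or compound 4.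

Compound 4 `COc1ccc(Cn2nc(-c3ccccc3)c3cc(C(=N)Nc4cccc(C(F)(F)F)c4)ncc32)cc1` differs from compound 3 by 4-methoxyphenyl in place of hydrogen on a saturated chain carbon bound to an aromatic nitrogen. Going by the values given here, no measured step covers this exchange; the only measured step concerned the aromatic nitrogen and did not move the number. Given that compound 1 sits at the limit > 50000 nM, a weaker number is expected for compound 4, with a 1.6-fold higher number from compound 3 to compound 4 (0.21 log units; within the scatter) as the estimated step. Compound 4 is estimated at 35000 nM, between 14000 nM and 90000 nM.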

Compound 4, half-maximal inhibitory concentration: > 50000 nM
Compound 4: a limit, no number; the forecaster's own chance of this, stated with the estimate: 40%; middle value at least 1.4-fold (0.15 log units) away from the limit.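

On the aromatic nitrogen, hydrogen and methyl could not be told apart, but 4-methoxybenzyl at this place does separate from both in this assay, with an at least 2.3-fold higher number from compound 3 to compound 4 (0.36 log units; beyond the scatter) and an at least 2.2-fold higher number from compound 2 to compound 4 (0.35 log units; beyond the scatter). On these data alone, both steps are lower bounds, and their true size remains unknown, since compound 4 gives > 50000 nM, which is a limit and not a number. The step between compound 1 and compound 4 cannot be read: the limit of > 50000 nM in this assay, at which 2 of the 4 values shown sit.

The compounds shown do not tell whether the higher number belongs to the benzyl part or to the methoxy group of the 4-methoxybenzyl group; an unsubstituted benzyl or an ethyl group on the aromatic nitrogen would separate these readings. As far as these compounds go, the effect of cyclohexylamino on the aromatic carbon also stays open with 4-methoxybenzyl in place.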